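The compounds below may be only part of what the source reports. "The series", "measured", "known", "first", "only" and "open" are said of these compounds alone.

Among the compounds with values here, compound 1 `CCc1cc(NCc2cccnc2)n2ncc(Br)c2n1` holds the lowest of the three numbers measured so far in a functional assay on cells (Homo sapiens), read by thymidine incorporation (a higher number here means a weaker inhibitor, a lower number a stronger inhibitor), where compound 1 gives 520 nM. Compound 3 `CSc1cc(NCc2cccnc2)n2ncc(Br)c2n1` gives 990 nM in this assay, and compound 2 `CC(O)c1cc(NCc2cccnc2)n2ncc(Br)c2n1` gives 1400 nM. Compound 4 `Brc1cnn2c(NCc3cccnc3)cc(C3CCCCC3)nc12` differs from compound 1 by cyclohexyl in place of ethyl on an aromatic carbon. Within the data shown here, the one precedent on the same aromatic carbon is a 1.9-fold higher number from compound 1 to compound 3 (0.28 log units; within the scatter), an exchange of one small group for another, while a 2.7-fold higher number from compound 1 to compound 2 (0.43 log units; beyond the scatter) concerns a saturated chain carbon instead. Among the measured compounds shown here, no measured compound carries a ring on that aromatic carbon, so the expectation rests on thin ground: a step of a 1.2-fold higher number from compound 1 to compound 4 (0.06 log units; within the scatter), not beyond the scatter, is expected. Compound 4 is therefore estimated at 600 nM, within a range from 220 nM to 1700 nM.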

Compound 4, half-maximal inhibitory concentration: 200 nM
Compound 4: middle estimate off by 3.0-fold (0.48 log units), on the high side; measured number below the stated range.
By their numbers in this assay, from the lowest: compound 4; then compounds 1, 3 and 2 (each within the scatter of the next, the first and the last beyond it).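

In this assay, within the data shown here, the aromatic carbon next to the ring nitrogen tolerates a six-membered carbon ring, and cyclohexyl gives the first step here to a lower number beyond the scatter, a 2.6-fold lower number from compound 1 to compound 4 (0.41 log units; beyond the scatter). Against the other two groups the steps are a 5.0-fold lower number from compound 3 to compound 4 (0.69 log units; beyond the scatter) and a 7.0-fold lower number from compound 2 to compound 4 (0.85 log units; beyond the scatter), so compound 4 alone stands beyond the scatter from all the others. No evidence here explains this change. Open, from the compounds shown here alone, is whether the ring itself matters or only the added carbons, which a longer chain such as hexyl, a phenyl ring or a piperidine ring on that carbon could separate.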